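This account rests on a few compounds, and the source may have more. Where it says the series, first, only, none or still open, it means among the compounds named here.

Working notes on the series. The single read-out is a functional assay on A549 cells (Homo sapiens) for cytotoxicity, with a stated time of 48 h; a higher number here means a weaker inhibitor, a lower number a stronger inhibitor. Compound 3 `Cc1cccc2oc(/C=C/[S+](C)[O-])cc(=O)c12` gives 1300 nM in this assay, and compound 2 `COc1cccc2oc(/C=C/[S+](C)[O-])cc(=O)c12` gives 3800 nM. Going by the values given here, the two differ in one place, (methoxy in place of methyl on an aromatic carbon), and that change produces a step of a 2.9-fold higher number from compound 3 to compound 2 (0.47 log units; beyond the scatter), the only step of its kind measured so far.

Compound 1 `Cc1cccc2c(=O)cc(/C=C/[S+](C)[O-])oc12` has the same atoms as compound 3 joined differently; the difference between the two cores is not broken down here. In this assay compound 1 gives 1700 nM. The values of compound 1 and compound 3 lie within the scatter of each other, so no order is drawn between them, while the value of compound 2 stands beyond the scatter from that of compound 1.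

Compound 4 `COc1cccc2c(=O)cc(/C=C/[S+](C)[O-])oc12` is not yet measured. It stands to compound 1 as compound 2 stands to compound 3: the change is methoxy in place of methyl on an aromatic carbon, and the surroundings of the place are described in the same words, so it is the same change. Among the compounds with values here, with only one prior instance of this change, the expectation rests wholly on the step seen between compound 3 and compound 2, and the range is kept wide. The expected step from compound 1 to compound 4 is a 2.6-fold higher number from compound 1 to compound 4 (0.42 log units; beyond the scatter). Compound 4 is therefore estimated at 4500 nM in this assay, with an expected range from 2200 nM to 9500 nM.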

Compound 4, half-maximal inhibitory concentration: 2200 nM
For compound 4 the middle estimate is 2.0-fold (0.31 log units) above the measured one, within the range that was stated.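

On the core of compound 1, methoxy in place of methyl gives, in this assay, a 1.3-fold higher number from compound 1 to compound 4 (0.11 log units; within the scatter), so the two groups are not told apart on this core. Set beside the same change on the core of compound 3, this step does not differ from the earlier one by more than repeated measurement allows: the same change on two cores in this assay, a 2.9-fold higher number (0.47 log units; beyond the scatter) from compound 3 to compound 2 and a 1.3-fold higher number (0.11 log units; within the scatter) from compound 1 to compound 4, 2.3-fold (0.35 log units) apart, within the scatter of two such steps The two cores are therefore compatible with one shared step for this change, but this does not show that the step is the same on both, since one step stands beyond the scatter and the other within it, and a single pair per core fixes neither its size nor its transfer to any further core.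

With only methyl and methoxy shown at this place, it remains open how a hydroxyl, an amine, a carboxylic acid or a longer chain such as ethoxy would read in this assay on either core. From the compounds shown here alone, all four compounds also carry the same sulfoxide side chain, so it remains equally open whether the small step between these two groups would persist with a sulfone there instead.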